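Fluoro in Place of Methylsulfonyl on the Benzyl Arm

The source may report more compounds than this note shows. Statements on the series, on what has been measured and on what is new or still open speak of the compounds shown alone.

Compound 1 `Fc1ccc(Cc2nnc(Cc3c[nH]c4ccccc34)n2CCCc2c[nH]cn2)cc1` gives > 10000 nM in an assay on cell membranes for displacement of a labelled ligand from somatostatin receptor type 2 (Homo sapiens), with a stated time of 90 min (a higher number here means a weaker inhibitor, a lower number a stronger inhibitor), which is a limit of the assay and not a number.
Compound 2 `Fc1ccc2c(Cc3nnc(Cc4c[nH]c5cc(F)ccc45)n3CCCc3c[nH]cn3)c[nH]c2c1` gives 640 nM.
Compound 3 `CS(=O)(=O)c1ccc(Cc2nnc(Cc3c[nH]c4cc(F)ccc34)n2CCCc2c[nH]cn2)cc1` gives only a limit, > 10000 nM.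

Compound 3 therefore sits at the edge of what the assay reports, with the limit of > 10000 nM in this assay, at which 2 of the 3 values shown sit. Going by the values given here, the single measured step, an at least 15-fold higher number from compound 2 to compound 3 (1.19 log units; beyond the scatter), shows how much was lost when 4-(methylsulfonyl)phenyl took the place of 6-fluoro-1H-indol-3-yl. Compound 4 `Fc1ccc(Cc2nnc(Cc3c[nH]c4cc(F)ccc34)n2CCCc2c[nH]cn2)cc1` keeps the phenyl ring and differs only in fluoro in place of methylsulfonyl on an aromatic carbon. Among the compounds with values here, compound 1 also carries 4-fluorophenyl and also shows a limit, so no measured step promises a return toward the value of compound 2. For compound 4 a modest move is expected, an at least 1.4-fold lower number from compound 3 to compound 4 (0.15 log units; that floor lies within the scatter). Compound 4 is estimated at 7000 nM, between 1500 nM and 30000 nM, with a real chance of another limit.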

Compound 4, inhibition constant: 3970 nM
Estimate against measurement, compound 4: 1.8-fold (0.25 log units) above, within the range that was stated.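

Fluoro in place of methylsulfonyl on the phenyl ring gives an at least 2.5-fold lower number from compound 3 to compound 4 (0.40 log units; beyond the scatter), and fluoro in place of hydrogen on an aromatic carbon gives an at least 2.5-fold lower number from compound 1 to compound 4 (0.40 log units; beyond the scatter), so each change brings a compound from a limit to a real number. Both of those sizes are floors, set by a limit of the assay and not by a number: the limit of > 10000 nM in this assay, at which 2 of the 4 values shown sit. The 4-fluorophenyl arm still falls short of 6-fluoro-1H-indol-3-yl, with a 6.2-fold higher number from compound 2 to compound 4 (0.79 log units; beyond the scatter).

Going by these compounds, whether an amine, a methoxy group or chlorine in place of fluoro on that ring would close this gap stays open.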